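Bromine compound with one double bond redrawn

A few compounds are considered here, and "the series" means these few. Any claim that something is new, unique, unknown or untested is made for them only; others in the source may bear on it.

Measured so far:
- compound 1 `CCCCC/C=C\C[C@]1(O)C=CC(=O)/C1=C/C=C/CCCC(=O)OC`: 5400 nM
- compound 2 `CCCCC/C=C\C[C@@]1(O)C=C(I)C(=O)/C1=C/C=C/CCCC(=O)OC`: 3900 nM
- compound 3 `CCCCC/C=C\C[C@@]1(O)C=C(Br)C(=O)/C1=C\C=C\CCCC(=O)OC`: 500 nM

All three values come from a functional assay on PC-3 cells (Homo sapiens) for cytotoxicity, read by sulforhodamine B assay, with a stated time of 72 h; on this read-out lower numbers stand for stronger inhibition and higher numbers for weaker inhibition. Compound 3 has the lowest number of the three, and both other compounds lie beyond the usual scatter from it.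

The next compound to be tested is compound 4 `CCCCC/C=C\C[C@@]1(O)C=C(Br)C(=O)/C1=C/C=C/CCCC(=O)OC`. Its structure differs from that of compound 3 only in shape: the two compounds have the same atoms and bonds and differ only in configuration as drawn: 1 of 4 stereo elements differ; a double bond is drawn Z in compound 3 and E in compound 4. Among the measured compounds shown here, no measured pair isolates a change of this kind, so any expectation here is tentative.

At this double bond, compound 4 is drawn like compound 2 at 3900 nM and like compound 1 at 5400 nM. Those two compounds also differ from compound 3 elsewhere, so they offer only a weak hint. A moderate move toward weaker inhibition is expected, and the estimated change is a 2.4-fold higher number from compound 3 to compound 4 (0.38 log units; beyond the scatter). For compound 4 the estimated value is 1200 nM, with an expected range from 350 nM to 4000 nM.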

Compound 4, half-maximal inhibitory concentration: 5600 nM
Compound 4: the middle estimate sits 4.7-fold (0.67 log units) below what was measured, and the stated range ends below it.
By their numbers in this assay, from the lowest: compound 3; then compounds 2, 1 and 4 (each within the scatter of the next).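

In this assay, redrawing one double bond from Z to E gives an 11-fold higher number from compound 3 to compound 4 (1.05 log units; beyond the scatter), so a change of shape alone can have a large effect at this position. This large step can be assigned to that double bond alone because no other feature separates the pair: the fact that compounds 3 and 4 differ only in the configuration as drawn With the double bond drawn E, bromo in place of iodo on a double-bonded ring carbon gives a 1.4-fold higher number from compound 2 to compound 4 (0.16 log units; within the scatter), which lies within the scatter, so bromo by itself does not bring the low number of compound 3.

From the compounds shown here alone, whether a Z double bond would have the same effect alongside iodo, or with chloro on that ring carbon, remains open. Going by these compounds, the effect of a carboxylic acid in place of the methyl ester is also open.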